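This account rests on a few compounds, and the source may have more. Where it says the series, first, only, none or still open, it means among the compounds named here.

Measured compounds:
- compound 1 `COc1cc2c(cc1C(C)NC/C=C/c1ccccc1)C=CC(C)(C)O2`: 83 nM
- compound 2 `COc1cc2c(cc1C(C)N[C@H](C)c1ccccc1)C=CC(C)(C)O2`: 232 nM
- compound 3 `CCNC(C)c1cc2c(cc1OC)OC(C)(C)C=C2`: 83 nM

In an assay on cell membranes for displacement of a labelled ligand from Sigma non-opioid intracellular receptor 1 (Cavia porcellus), read by scintillation counting (a lower number here means a stronger inhibitor, a higher number a weaker inhibitor), compound 3 gives 83 nM, level with compound 1 at the digits shown, and these two stand together as the lowest numbers of the three. Among the measured compounds shown here, the only measured compound set apart is compound 2; the step of a 2.8-fold lower number from compound 2 to compound 3 (0.45 log units; beyond the scatter) is modest but beyond the scatter, whereas no change at the digits printed from compound 1 to compound 3 (within the scatter) shows no change.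

Compound 4 `CCN(CC)CCCC(C)NC(C)c1cc2c(cc1OC)OC(C)(C)C=C2` differs from compound 3 by the change (3-(diethylamino)propyl in place of hydrogen on a saturated chain carbon bound to an amine nitrogen and a saturated chain carbon). For the measured compounds named here, the nearest precedent is the step between compound 2 and compound 3, where a phenyl at the same place gave a somewhat higher number than hydrogen; the other step, from compound 1 to compound 3, concerns a different carbon and shows no change. Neither step involves a chain carrying a second amine nitrogen, so the precedent is loose. The expectation is therefore a small step at most in this assay, most likely within or just beyond the scatter, with the direction uncertain; the estimated step is a 1.2-fold lower number from compound 3 to compound 4 (0.07 log units; within the scatter). On that basis compound 4 is expected to give about 70 nM in this assay, with a likely range from 20 nM to 250 nM.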

Compound 4, inhibition constant: 192 nM
Compound 4: middle estimate off by 2.7-fold (0.44 log units), on the low side; low and high end bracket the measured number.
By their numbers in this assay, from the lowest: compounds 1 and 3 (each within the scatter of the next); then compounds 4 and 2 (each within the scatter of the next).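

In this assay, putting the 3-(diethylamino)propyl chain on the saturated chain carbon bound to an amine nitrogen and a saturated chain carbon gives a 2.3-fold higher number from compound 3 to compound 4 (0.36 log units; beyond the scatter), so this position responds to a long chain that carries a further amine nitrogen, although the step is only modest. Read alongside a 2.8-fold lower number from compound 2 to compound 3 (0.45 log units; beyond the scatter), this means that hydrogen at this carbon gives a lower number than either of the two larger groups shown, a phenyl and the 3-(diethylamino)propyl chain, even though those groups are very different; compound 2 at 232 nM and compound 4 at 192 nM lie within the scatter of each other. Nothing shown here offers a reason for these steps.

As far as these compounds go, what remains open is whether the higher number follows from the length of the chain or from the diethylamino group at its end, a question that a plain butyl chain with no nitrogen and a shorter 2-(diethylamino)ethyl chain could help to separate. From the compounds shown here alone, it is also open how this position would respond to a chain ending in a carboxylic acid or in a morpholine.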